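The compounds below may be only part of what the source reports. "The series", "measured", "known", "first", "only" and "open" are said of these compounds alone.

Measured in an ADME assay on BHK-21 cells (Mesocricetus auratus) for cytotoxicity, read by MTT assay, with a stated time of 72 h; on this read-out lower numbers stand for higher toxicity in this test and higher numbers for lower toxicity in this test:
compound 1 `Cc1ccc(C2CC(c3ccccc3)=NN2c2ccc(S(N)(=O)=O)cc2)cc1` gives 7000 nM
compound 2 `NS(=O)(=O)c1ccc(N2N=C(c3ccc(Oc4ccccc4)cc3)CC2c2ccccc2)cc1` gives 11000 nM
compound 3 `NS(=O)(=O)c1ccc(N2N=C(c3ccc(Oc4ccccc4)cc3)CC2c2cccc(F)c2)cc1` gives 10000 nM

Compound 3 lies within the scatter of both other compounds, so these values set no order. Next comes compound 4 `Cc1ccc(C2CC(c3ccc(Oc4ccccc4)cc3)=NN2c2ccc(S(N)(=O)=O)cc2)cc1`, which differs from compound 3 as follows: 4-methylphenyl in place of 3-fluorophenyl on a saturated ring carbon. In words, 4-methylphenyl replaces 3-fluorophenyl on a saturated ring carbon. Within the data shown here, the only measured step, a 1.1-fold lower number from compound 2 to compound 3 (0.04 log units; within the scatter), changes the aromatic group on that same carbon and stays within the scatter. Compound 1 already carries 4-methylphenyl there, and its value is also within the scatter of compound 3. No step beyond the scatter is therefore expected in this assay, and no direction is favoured. The estimated change is a 1.1-fold lower number from compound 3 to compound 4 (0.05 log units; within the scatter). For compound 4 the expected value is 9000 nM (estimated range 5000 nM to 16000 nM).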

Compound 4, half-maximal cytotoxic concentration: 8000 nM
Compound 4: the middle estimate sits 1.1-fold (0.05 log units) above what was measured; the measured number falls inside the stated range.
By their numbers in this assay, from the lowest: compounds 1, 4, 3 and 2 (each within the scatter of the next).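

In this assay, 4-methylphenyl in place of 3-fluorophenyl on the saturated ring carbon stays within the scatter (a 1.3-fold lower number from compound 3 to compound 4 (0.10 log units; within the scatter)), as does methyl in place of hydrogen on that ring's aromatic group (a 1.4-fold lower number from compound 2 to compound 4 (0.14 log units; within the scatter)). With 4-methylphenyl held on that carbon, the added phenoxy group also stays within the scatter (a 1.1-fold higher number from compound 1 to compound 4 (0.06 log units; within the scatter)). No supporting evidence bears on these readings.
Still open, from the compounds shown here alone, is whether an amine or a carboxylic acid on the aromatic group at that saturated ring carbon would give a step beyond the scatter.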